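This account rests on a few compounds, and the source may have more. Where it says the series, first, only, none or still open, it means among the compounds named here.

Compound 1 `COc1ccc(C(=O)NNc2c(Br)cccc2Br)cc1` was examined in a toxicity assay on MDCK cells (Canis lupus familiaris) for cytotoxicity, read by CCK-8 assay, with a stated time of 48 h; on this read-out lower numbers stand for higher toxicity in this test and higher numbers for lower toxicity in this test. Here compound 1 gives > 100000 nM, which is a limit of the assay rather than a number. Compound 2 `CCOc1ccc(C(=O)NNc2c(C)cccc2C)cc1` gives > 100000 nM, again only a limit. Compound 3 `Cc1cccc(C)c1NNC(=O)c1ccc(C(C)(C)C)cc1` gives > 100000 nM, likewise a limit. Among the compounds with values here, the one change among them, a step that the two limits leave unreadable from compound 2 to compound 3, therefore carries no readable size, and the limit of > 100000 nM in this assay, at which 3 of the 3 values shown sit, is all the evidence there is. Compound 4 `O=C(O)c1ccc(C(=O)NNc2c(Br)cccc2Br)cc1` differs from compound 1 by carboxy in place of methoxy on an aromatic carbon. Within the data shown here, no measured step resembles this change, and every measured value sits at the limit, so no direction beyond the scatter can be read. Compound 4 is therefore expected to give about 150000 nM, from 50000 nM to 500000 nM. The expected step is a step that the limit leaves unreadable from compound 1 to compound 4.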

Compound 4, half-maximal cytotoxic concentration: > 100000 nM
Compound 4: no number, only a limit; the forecaster's own chance of this, stated with the estimate: 80%; the middle value lies beyond the limit too.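

Within the data shown here, compound 1 and compound 4 both give only a limit, so no step between them can be read: the limit of > 100000 nM in this assay, at which 4 of the 4 values shown sit. The compounds shown leave open whether any change to the shared core shifts the result in this assay.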